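A piperazinyl amide tested against three sulfanyl amides

The source may report more compounds than this note shows. Statements on the series, on what has been measured and on what is new or still open speak of the compounds shown alone.

Three amides sharing one core have been measured: compound 1 `Cn1c(-c2ccc(NC(=O)CSc3nc4ccccc4o3)cc2)nc(-c2ccccc2)c1-c1ccccc1`, compound 2 `Cn1c(-c2ccc(NC(=O)CSc3nc4ccccc4s3)cc2)nc(-c2ccccc2)c1-c1ccccc1` and compound 3 `Cn1ccnc1SCC(=O)Nc1ccc(-c2nc(-c3ccccc3)c(-c3ccccc3)n2C)cc1`. In a functional assay on HT-29 cells (Homo sapiens) for cytotoxicity, read by MTT assay, with a stated time of 24 h, tested at 0.64 ug/mL (a lower number here means a weaker effect, a higher number a stronger effect of the compound at the concentration tested), compound 1 gives 24.8%, compound 2 gives 9.8% and compound 3 gives 13.6%. Compound 3 thus stands second highest of the three: the step of a number 3.8 percentage points higher from compound 2 to compound 3 (within the scatter) lies within the scatter, whereas a number 11.2 percentage points lower from compound 1 to compound 3 (beyond the scatter). Compound 4 `CN(C)/C=C/N1CCN(CC(=O)Nc2ccc(-c3nc(-c4ccccc4)c(-c4ccccc4)n3C)cc2)CC1` differs from compound 3 in one place: 4-(2-(dimethylamino)ethenyl)piperazin-1-yl in place of (1-methyl-1H-imidazol-2-yl)sulfanyl on a saturated chain carbon bound to a carbonyl carbon. Among the measured compounds shown here, no measured step removes the sulfanyl group itself; the steps of a number 15 percentage points lower from compound 1 to compound 2 (beyond the scatter) and a number 11.2 percentage points lower from compound 1 to compound 3 (beyond the scatter) only swap the ring on the sulfur and were modest. With nothing closer to lean on, the step of a number 0.6 percentage points lower from compound 3 to compound 4 (within the scatter) is expected to stay within the scatter. Compound 4 is therefore estimated at 13%, between 2% and 30%.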

Compound 4, a percentage reported as activity, at one concentration (the size of the read-out at that concentration, not a potency): 3.1%
Beside the measured number, compound 4's estimate is 9.9 percentage points above it; low and high end bracket the measured number.
By their numbers in this assay, from the lowest: compounds 4, 2 and 3 (each within the scatter of the next, the first and the last beyond it); then compound 1.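

Swapping the whole sulfanyl group for 4-(2-(dimethylamino)ethenyl)piperazin-1-yl on this saturated chain carbon shows that the position accepts a group without sulfur, but the number in this assay falls: the change gives a number 10.5 percentage points lower from compound 3 to compound 4 (beyond the scatter) and a number 21.7 percentage points lower from compound 1 to compound 4 (beyond the scatter) for two of the sulfanyl amides. Against the third it gives a number 6.7 percentage points lower from compound 2 to compound 4 (within the scatter), so the size of the change depends on the sulfanyl group replaced. No measurement shown here explains these steps.

Whether the piperazine ring or the 2-(dimethylamino)ethenyl group on it accounts for the drop stays open. A plain piperazin-1-yl or a morpholin-4-yl group on the same carbon would separate the two.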